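The compounds below may be only part of what the source reports. "The series", "measured", "known", "first", "only" and "open" are said of these compounds alone.

Measured so far:
compound 1, `C=C[C@@](C)(/C=C/c1ccc(O)c(CO)c1)CCC=C(C)C`, in a functional assay on SEM cells (Homo sapiens) for cytotoxicity, with a stated time of 72 h (a higher number here means that more compound is needed for the effect, a lower number that less compound is needed), compound 1 gives > 36600 nM;
compound 2, `C=C[C@@](C)(/C=C/c1ccc(Nc2ccc(OC)cc2)cc1)CCC=C(C)C`, in this assay compound 2 gives > 36600 nM.

The value of compound 2 is a limit of the assay, not a number. The value of compound 1 is a limit as well. So compound 2 stands where the whole measured set stands, at the limit of > 36600 nM in this assay, at which 2 of the 2 values shown sit. Compound 3, `C=C[C@@](C)(/C=C/c1ccc(Nc2ccc(Cl)cc2)cc1)CCC=C(C)C`, has not yet been tested. It differs from compound 2 in one place: chloro in place of methoxy on an aromatic carbon. Within the data shown here, no measured step between two compounds is available, so nothing in these data shows how such a change moves the result; with every value shown sitting at the limit, no step beyond the scatter is expected in this assay. Compound 3 is expected to give about 40000 nM, in the range 10000 nM to 120000 nM, most probably again reported only as a limit. That estimate corresponds to a step that the limit leaves unreadable from compound 2 to compound 3.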

Compound 3, half-maximal effective concentration: > 36600 nM
Compound 3: no number, only a limit; the forecaster's own chance of this, stated with the estimate: 75%; the middle value is on the limit's open side.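

Among these compounds, compound 2 and compound 3 both sit at a limit, not at a number, so no step between them can be read for chloro in place of methoxy: the limit of > 36600 nM in this assay, at which 3 of the 3 values shown sit. The compounds shown leave open how far past that limit each lies in this assay and which change to the shared core would give a measurable value.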